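The source may hold more compounds than are shown below. What is called first, only, known or untested is meant among the compounds shown, and "the series" means these compounds.

Working notes on the series. In a functional assay on Jurkat cells (Homo sapiens) for antiproliferative activity, read by MTT assay, with a stated time of 72 h (on this read-out lower numbers stand for stronger inhibition and higher numbers for weaker inhibition), compound 1 (`COc1cc(C(=O)c2sc3ccccc3c2-c2ccc(F)cc2)cc(OC)c1OC`) gives 2300 nM and compound 2 (`COc1cc(C(=O)c2sc3ccccc3c2-c2ccc(SC)cc2)cc(OC)c1OC`) gives 1900 nM. With only these two numbers available, compound 2 stands level with compound 1, and no ranking can be drawn between them.

Compound 3 (`COc1ccccc1-c1c(C(=O)c2cc(OC)c(OC)c(OC)c2)sc2ccccc12`) comes next, and the change from compound 2 is 2-methoxyphenyl in place of 4-(methylsulfanyl)phenyl on an aromatic carbon. In words, it is 2-methoxyphenyl in place of 4-(methylsulfanyl)phenyl on an aromatic carbon of a five-membered aromatic ring with 1 sulfur. Within the data shown here, no measured compound carries the 2-methoxyphenyl group, so there is no direct precedent for it.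

Among the measured compounds shown here, the only measured step that bears on this change is a 1.2-fold lower number from compound 1 to compound 2 (0.08 log units; within the scatter), where methylsulfanyl replaced fluoro on an aromatic carbon. On that single step, no shift beyond the scatter is expected in this assay, although one step is thin evidence and the range must stay wide. The expected change is a 1.3-fold higher number from compound 2 to compound 3 (0.12 log units; within the scatter). The estimate for compound 3 is 2500 nM, with an expected range of 800 nM to 8000 nM.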

Compound 3, half-maximal inhibitory concentration: 2900 nM
Estimate against measurement, compound 3: 1.2-fold (0.06 log units) below; the range from low to high includes it.
By their numbers in this assay, from the lowest: compounds 2, 1 and 3 (each within the scatter of the next).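

Among these compounds, compound 3 brings the first change of the whole aryl group at this place, on an aromatic carbon of a five-membered aromatic ring with 1 sulfur, whereas compound 1 and compound 2 differ only in the group carried by a 4-substituted phenyl. In this assay, the exchange of 4-(methylsulfanyl)phenyl for 2-methoxyphenyl gives a 1.5-fold higher number from compound 2 to compound 3 (0.18 log units; within the scatter) and the exchange of 4-fluorophenyl for 2-methoxyphenyl gives a 1.3-fold higher number from compound 1 to compound 3 (0.10 log units; within the scatter) in the same read-out, so all three compounds stand level and neither change separates compound 3 from the other two. No measurement of another kind bears on this result, and the level values remain without an explanation.

Compound 3 differs from compound 1 and compound 2 both in the group on the phenyl and in where that group sits, so a 4-methoxyphenyl group would be needed to tell these two changes apart. On these data alone, it also remains open whether an aminophenyl or carboxyphenyl group, or a longer alkyl chain in place of the aryl ring, would move the number beyond the scatter at this place.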